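The source may report more compounds than this note shows. Statements on the series, on what has been measured and on what is new or still open speak of the compounds shown alone.

In a functional assay on HeLa cells (Homo sapiens) for antiproliferative activity, read by MTT assay, with a stated time of 48 h (on this read-out lower numbers stand for stronger inhibition and higher numbers for weaker inhibition), compound 1, whose structure is `Cn1cc(-c2cnc3ccc(NCc4ccc(F)cc4)nc3c2)cn1`, gives 46600 nM. Compound 2, with the structure `COc1ccc(CNc2ccc3ncc(-c4cnn(C)c4)cc3n2)cc1`, differs from it by methoxy in place of fluoro on an aromatic carbon. In this assay compound 2 reaches only the limit of the assay, > 50000 nM. The step of an at least 1.0-fold higher number from compound 1 to compound 2 (0.03 log units; that floor lies within the scatter) is therefore a floor rather than a number, because of the limit of > 50000 nM in this assay, at which 2 of the 3 values shown sit.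

Compound 3 has the structure `Cn1cc(-c2cnc3ccnc(NC(=O)c4ccc(F)cc4)c3c2)cn1`; how its core differs from the core of compound 1 is not broken down here. In this assay compound 3 likewise sits at the limit of the assay, > 50000 nM.

Going by the values given here, compound 4, with the structure `COc1ccc(C(=O)Nc2nccc3ncc(-c4cnn(C)c4)cc23)cc1`, is still to be measured and differs from compound 3 by methoxy in place of fluoro on an aromatic carbon, the same change as the one from compound 1 to compound 2. For compound 4 the expected step that the limit leaves unreadable from compound 3 to compound 4 rests on compound 3 being a limit > 50000 nM and on the earlier step of an at least 1.0-fold higher number from compound 1 to compound 2 (0.03 log units; that floor lies within the scatter) giving no gain. Compound 4 is thus estimated to give about 70000 nM, most likely again reported only as a limit.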

Compound 4, half-maximal inhibitory concentration: > 50000 nM
Compound 4 gave a limit, no number; the forecaster's own chance of this, stated with the estimate: 85%; the middle value lies beyond the limit too.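

No step can be read between compound 3 and compound 4, as both stand only at a limit: the limit of > 50000 nM in this assay, at which 3 of the 4 values shown sit.

The compounds shown leave open whether 4-methoxyphenyl in place of 4-fluorophenyl changes the result at all in this assay.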